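The source may report more compounds than this note shows. Statements on the series, on what has been measured and on what is new or still open speak of the compounds shown alone.

Measured compounds:
- compound 1, `CC[C@@H]1C(=O)N(C)c2cnc(-n3ccc4cc(F)ccc43)nc2N1C1CCCC1`: > 20000 nM
- compound 2, `CCC1C(=O)N(C)c2cnc(-n3ccc4cc(C(=O)NCC(C)C)ccc43)nc2N1c1ccn(C)n1`: > 10000 nM

In an assay for inhibition of serine/threonine-protein kinase PLK3 (Homo sapiens), read by FRET and Z'-LYTE, with a stated time of 1 h (a higher number here means a weaker inhibitor, a lower number a stronger inhibitor), compound 1 gives > 20000 nM, and this is a limit of the assay rather than a measured number. Compound 2, which shares the same core but carries an isobutyl amide on its fused ring system and a different group on the core nitrogen, also stops at a limit: in this assay compound 2 gives > 10000 nM. Compound 1 therefore stands at the weak end of what is shown, with both values being limits, one at the limit of > 10000 nM in this assay, at which 1 of the 2 values shown sits, and one at the limit of > 20000 nM in this assay, at which 1 of the 2 values shown sits.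

Compound 3, `CC[C@@H]1C(=O)N(C)c2cnc(-n3ccc4cc(C(=O)NC5CCCC5)ccc43)nc2N1C1CCCC1`, is the untested compound. It differs from compound 1 in one place: cyclopentylcarbamoyl in place of fluoro on an aromatic carbon. Among the compounds with values here, no step between two measured compounds is available for this kind of change. Compound 2, which carries an amide of a related kind on the same fused ring system, also sits at a limit, so no gain beyond the usual scatter is expected from the change. The expectation for compound 3 in this assay is 20000 nM, with a range from 5000 nM to 60000 nM, which amounts to an expected step of a number no higher from compound 1 to compound 3 (the limit leaves the size open).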

Compound 3, half-maximal inhibitory concentration: > 20000 nM
Compound 3 gave a limit, no number; the forecaster's own chance of this, stated with the estimate: 75%; the middle value sits exactly at the limit.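

In this assay no step can be read from compound 1 to compound 3, because both compounds stop at the same limit rather than at a measured number: the limit of > 20000 nM in this assay, at which 2 of the 3 values shown sit. The compounds shown leave open how cyclopentylcarbamoyl compares with fluoro at this place, and what change, if any, would give a measured number in this assay.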